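Swapping a methyl for a methoxy on the amide ring

The source may hold more compounds than are shown below. What is called first, only, known or untested is meant among the compounds shown, and "the series" means these compounds.

Compound 1 `Cc1ccccc1C(=O)NC(CCN(C)C)c1ccc(Cl)cc1`: 175%
Compound 2 `COc1ccc(C(=O)NC(CCN(C)C)c2ccc(Cl)cc2)cc1`: 162%
Compound 3 `Cc1cccc(C(=O)NC(CCN(C)C)c2ccc(Cl)cc2)c1C`: 159%

The three measured compounds share one core and differ only in the aromatic ring attached to the carbonyl. In an assay on NIH3T3 cells with Urotensin-2 receptor (Homo sapiens) as the target (on this read-out lower numbers stand for smaller maximal responses and higher numbers for larger maximal responses), compound 3 gives the lowest of the three numbers; the nearest step is a number 3 percentage points lower from compound 2 to compound 3 (within the scatter), and the furthest is a number 16 percentage points lower from compound 1 to compound 3 (beyond the scatter). Compound 4 `COc1cccc(C(=O)NC(CCN(C)C)c2ccc(Cl)cc2)c1C` has not yet been measured and differs from compound 3 by methoxy in place of methyl on an aromatic carbon. Among the compounds with values here, the only measured step that also brings a methoxy in is a number 13 percentage points lower from compound 1 to compound 2 (beyond the scatter), a modest change, and the present swap is a smaller one. Compound 4 is therefore expected to give 155%, somewhere between 138% and 172%. Compound 4 is thus expected to show a number 4 percentage points lower from compound 3 to compound 4 (within the scatter).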

Compound 4, largest response reached (reported as efficacy), in percent of the reference or control that the assay uses: 179%
For compound 4 the middle estimate is 24 percentage points below the measured one; the measured number lies above the stated range.
By their numbers in this assay, from the lowest: compounds 3 and 2 (each within the scatter of the next); then compounds 1 and 4 (each within the scatter of the next).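

On this aromatic carbon, methoxy in place of methyl gives a number 20 percentage points higher from compound 3 to compound 4 (beyond the scatter), so the two groups are not interchangeable here. Starting from hydrogen on the same carbon, methoxy gives a number 4 percentage points higher from compound 1 to compound 4 (within the scatter), whereas methyl gives a number 16 percentage points lower from compound 1 to compound 3 (beyond the scatter), so only the methyl step lies beyond the scatter. No measurement available here explains this difference.

From the compounds shown here alone, it remains open how a hydroxyl, an amine or a longer ethoxy chain on this carbon would compare. Also open, going by these compounds, is whether methoxy would give the same result without the ortho methyl group.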